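A few compounds are considered here, and "the series" means these few. Any claim that something is new, unique, unknown or untested is made for them only; others in the source may bear on it.

For the measured compounds named here, in a functional assay on OVCAR-5 cells (Homo sapiens) for inhibition, read by CCK-8 assay, with a stated time of 72 h, tested at 1 uM (a lower number here means less inhibition of growth, a higher number more inhibition of growth at the concentration tested), compound 2 (`CN(C)C(=O)c1cc2cnc(Nc3ccc(NC(=O)C4(C(=O)Nc5ccc(Br)cc5)CC4)cc3)nc2n1C1CCCC1`) gives 13.7%, the lower of the two numbers so far, and compound 1 (`CN(C)C(=O)c1cc2cnc(Nc3ccc(NC(=O)C4(C(=O)Nc5cccc(F)c5)CC4)cc3)nc2n1C1CCCC1`) gives 26.3%. Compound 3 (`CN(C)C(=O)c1cc2cnc(Nc3ccc(NC(=O)C4(C(=O)Nc5ccc(Cl)c(C(F)(F)F)c5)CC4)cc3)nc2n1C1CCCC1`) carries 4-chloro-3-(trifluoromethyl)phenyl in place of 4-bromophenyl on an amide-type nitrogen. Going by the values given here, one measured step bears on this place, a number 12.6 percentage points lower from compound 1 to compound 2 (beyond the scatter), modest and beyond the scatter. It compares a different pair of groups and sets no firm direction, so only a slight rise within the scatter is expected in this assay. The expected step is a number 6.3 percentage points higher from compound 2 to compound 3 (within the scatter). For compound 3 the estimate is 20%, with an expected range of 5% to 38%.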

Compound 3, percent growth inhibition at one concentration: -2.4%
For compound 3 the middle estimate is 22.4 percentage points above the measured one, and the stated range ends above it.
By their numbers in this assay, from the lowest: compound 3; then compound 2; then compound 1.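

Notes on the group on the amide-type nitrogen: in this assay this place moves the read-out further than the first pair showed, with a number 16.1 percentage points lower from compound 2 to compound 3 (beyond the scatter) and a number 28.7 percentage points lower from compound 1 to compound 3 (beyond the scatter). Of the three aryl groups shown, 4-chloro-3-(trifluoromethyl)phenyl, with 11 heavy atoms against 7 for 4-bromophenyl, gives the lowest number, and each step down is beyond the scatter. No measured evidence accounts for this drop. Still open, going by these compounds, is whether the 4-chloro or the 3-(trifluoromethyl) part alone carries the step. Also open, on these data alone, is how a phenyl ring bearing an amine or a carboxylic acid would read here.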